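Lengthening the ether chain on a trimethoxyphenyl chromone core

The compounds below may be only part of what the source reports. "The series", "measured", "known", "first", "only" and "open" are said of these compounds alone.

Measured so far:
- compound 1, `CCOc1c(-c2cc(OC)c(OC)c(OC)c2)oc2ccccc2c1=O`: 900 nM
- compound 2, `CCCCOc1c(-c2cc(OC)c(OC)c(OC)c2)oc2ccccc2c1=O`: 12800 nM
- compound 3, `CCCCCCOc1c(-c2cc(OC)c(OC)c(OC)c2)oc2ccccc2c1=O`: 29200 nM

These three compounds share one core and differ only in the length of the chain attached through the oxygen on the aromatic ring. In a functional assay on PC-3 cells (Homo sapiens) for antiproliferative activity, read by WST assay, with a stated time of 3 days (a higher number here means a weaker inhibitor, a lower number a stronger inhibitor), compound 1 gives the lowest number of the three, so it is the strongest inhibitor shown. Each lengthening of the chain weakens it: there is a 14-fold higher number from compound 1 to compound 2 (1.15 log units; beyond the scatter) and a 32-fold higher number from compound 1 to compound 3 (1.51 log units; beyond the scatter), and between the two longer chains a 2.3-fold higher number from compound 2 to compound 3 (0.36 log units; beyond the scatter).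

Compound 4, `CCN(CC)CCCCOc1c(-c2cc(OC)c(OC)c(OC)c2)oc2ccccc2c1=O`, has not yet been measured. Compared with compound 1 it carries 2-(diethylamino)ethyl in place of hydrogen on a saturated chain carbon, two bonds along the chain from an oxygen on an aromatic ring. The change therefore lengthens the same chain that the measured steps lengthen, now with a nitrogen in it. The steps from compound 1 to compound 2 and from compound 1 to compound 3 are the ones that bear on this, and both were large in the weakening direction. Within the data shown here, no measured compound shows what the nitrogen alone does, so the expectation rests on chain length. For compound 4 a step of about an 8.9-fold higher number from compound 1 to compound 4 (0.95 log units; beyond the scatter) is expected, toward a higher number. Compound 4 is thus estimated at 8000 nM in this assay, within a range from 2000 nM to 40000 nM.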

Compound 4, half-maximal inhibitory concentration: 13700 nM
The estimate for compound 4 lay 1.7-fold (0.23 log units) below the measured number; the measured number falls inside the stated range.
By their numbers in this assay, from the lowest: compound 1; then compounds 2 and 4 (each within the scatter of the next); then compound 3.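

In this assay, 2-(diethylamino)ethyl in place of hydrogen on the chain still costs a large step, a 15-fold higher number from compound 1 to compound 4 (1.18 log units; beyond the scatter), so a nitrogen-bearing chain of this length does not recover the number of the short ethoxy chain. Further along the chain, four bonds from the oxygen on the aromatic ring, diethylamino in place of hydrogen leaves no difference beyond the scatter, a 1.1-fold higher number from compound 2 to compound 4 (0.03 log units; within the scatter), while diethylamino in place of ethyl gives a modest step toward a stronger inhibitor, a 2.1-fold lower number from compound 3 to compound 4 (0.33 log units; beyond the scatter), so at this place the amine does no harm beyond what a plain chain of similar reach already costs. Nothing available here accounts for why these numbers move as they do.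

Still open, from the compounds shown here alone, is whether a diethylamino group on a shorter chain, such as 2-(diethylamino)ethoxy in place of ethoxy, would keep the number of compound 1, and whether a ring amine such as morpholine or a carboxylic acid at the chain end would read differently from diethylamino. The shorter side of the series is also open, since a methoxy group or a free hydroxyl in place of ethoxy would show whether the ethoxy chain is the best length or just the shortest one shown.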